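The source may report more compounds than this note shows. Statements on the series, on what has been measured and on what is new or still open speak of the compounds shown alone.

Within the data shown here, compound 2 `CC(C(=O)NCc1ccc(C(F)(F)F)nc1N(C)C)c1ccc(NS(C)(=O)=O)c(F)c1` gives 2390 nM in a functional assay on CHO-K1 cells for antagonist activity at transient receptor potential cation channel subfamily V member 1 (Homo sapiens), read by FLIPR (a lower number here means a stronger inhibitor, a higher number a weaker inhibitor), and stands highest of the two numbers so far, though only within the scatter of compound 1. Compound 1 `CC(C(=O)NCc1ccc(C(F)(F)F)nc1Nc1ccccc1)c1ccc(NS(C)(=O)=O)c(F)c1` gives 1400 nM in this assay. Among the measured compounds shown here, the single measured step, a 1.7-fold higher number from compound 1 to compound 2 (0.23 log units; within the scatter), is the only one that bears on the amine position. Compound 3 `CCCN(CCC)c1nc(C(F)(F)F)ccc1CNC(=O)C(C)c1ccc(NS(C)(=O)=O)c(F)c1` differs from compound 2 by dipropylamino in place of dimethylamino on an aromatic carbon. For the measured compounds named here, no measured step alters the size of the alkyl groups on this amine, so for compound 3 the expected step is a 1.5-fold lower number from compound 2 to compound 3 (0.17 log units; within the scatter), not beyond the scatter. Compound 3 is estimated at 1600 nM, with a range of 500 nM to 5000 nM.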

Compound 3, half-maximal inhibitory concentration: 14.7 nM
Estimate against measurement, compound 3: 110-fold (2.04 log units) above; measured number outside the range, below it.
By their numbers in this assay, from the lowest: compound 3; then compounds 1 and 2 (each within the scatter of the next).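

In this assay the amine at this position matters far more than compound 1 and compound 2 suggested, with dipropylamino giving a 160-fold lower number from compound 2 to compound 3 (2.21 log units; beyond the scatter) and a 95-fold lower number from compound 1 to compound 3 (1.98 log units; beyond the scatter) in the same comparison. Anilino and dimethylamino stand within the scatter of each other, so only dipropylamino separates from the rest. Nothing at hand accounts for this gain. As far as these compounds go, whether diethylamino or dibutylamino would sit at a similar level remains open. So does whether a single propyl chain, as in methylpropylamino, or a cyclic amine such as piperidine would suffice.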